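Two weakly cytotoxic compounds and an untested relative

A few compounds are considered here, and "the series" means these few. Any claim that something is new, unique, unknown or untested is made for them only; others in the source may bear on it.

Measured in a functional assay on HCT-116 cells (Homo sapiens) for cytotoxicity, read by sulforhodamine B assay, with stated times of 4 h and 5 days; on this read-out higher numbers stand for weaker inhibition and lower numbers for stronger inhibition:
- compound 1, `COCCNS(=O)(=O)CCn1cncc1[N+](=O)[O-]`, gives 4400000 nM
- compound 2, `COCCCNS(=O)(=O)CCn1c([N+](=O)[O-])cnc1C`, gives 3700000 nM

Both numbers lie far up the concentration scale, so each compound is only a weak inhibitor of cell growth. Compound 2 has the lower of the two numbers, but the gap to compound 1 falls within the usual scatter, so the two compounds cannot be told apart on this basis. Compound 3, `Cc1ncc([N+](=O)[O-])n1CCS(=O)(=O)N1CCN(C)CC1`, is not yet measured; it differs from compound 2 in one place: 4-methylpiperazin-1-yl in place of (3-methoxypropyl)amino on a sulfonyl sulfur. Among the compounds with values here, no measured pair shows what exchanging this group does, so the expectation rests only on the weak activity of compound 2. The step from compound 2 to compound 3 is expected to be a 1.1-fold higher number from compound 2 to compound 3 (0.03 log units; within the scatter), that is, nothing beyond the scatter. Compound 3 is therefore estimated at 4000000 nM, with a plausible range from 1300000 nM to 12000000 nM.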

Compound 3, half-maximal inhibitory concentration: 1600000 nM
Beside the measured number, compound 3's estimate is 2.5-fold (0.40 log units) above it, and the stated range covers the measured number.
By their numbers in this assay, from the lowest: compound 3; then compounds 2 and 1 (each within the scatter of the next).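

On a sulfonyl sulfur, the choice of group can shift activity in this assay: putting 4-methylpiperazin-1-yl in place of (3-methoxypropyl)amino gives a 2.3-fold lower number from compound 2 to compound 3 (0.36 log units; beyond the scatter) and this modest step lies beyond the scatter, even though compound 3 still acts only weakly at 1600000 nM. The exchange replaces an open chain carrying a hydrogen-bond donor with a six-membered ring carrying none, so several features change together and this single pair cannot separate them. No measurement here explains the shift.

The compounds shown do not reveal whether the ring or its methyl group matters, a question that piperazin-1-yl without the methyl, morpholin-4-yl or a simple dimethylamino group could help answer. They also leave open whether the same exchange would have a similar effect on the core of compound 1.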